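Replacing the 2,4-difluorophenyl group of compound 1

This account rests on a few compounds, and the source may have more. Where it says the series, first, only, none or still open, it means among the compounds named here.

- compound 1 `O=C(Nc1cc(F)c(F)c(F)c1)N1Cc2c(-c3ccc(F)cc3F)cnn2CC1C1CC1`: 32100 nM
- compound 2 `CC1CCn2ncc(N3CC(c4ccccc4)CC3=O)c2CN1C(=O)Nc1cc(F)c(F)c(F)c1`: > 2000 nM (a limit)
- compound 3 `O=C1OC(c2ccc(F)cc2)CN1c1cnn2c1CN(C(=O)Nc1cc(F)c(F)c(F)c1)C(C1CC1)C2`: 3560 nM

In a toxicity assay on HepG2 2.2.15 cells (Homo sapiens) for cytotoxicity, read by CellTiter-Glo (on this read-out lower numbers stand for higher toxicity in this test and higher numbers for lower toxicity in this test), compound 1 gives 32100 nM, the higher of the two actual numbers, and its nearest neighbour, compound 3, lies lower by more than the scatter. The entry for compound 2 is a limit and not a number.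

Compound 4 `CC1(C)CC(=O)N(c2cnn3c2CN(C(=O)Nc2cc(F)c(F)c(F)c2)C(C2CC2)C3)C1`, not yet measured, has 4,4-dimethyl-2-oxopyrrolidin-1-yl in place of 2,4-difluorophenyl on an aromatic carbon. Among the compounds with values here, no measured pair shows this change. Within the data shown here, with compound 3 at 3560 nM as the only other number, the expected step of a 3.2-fold lower number from compound 1 to compound 4 (0.51 log units; beyond the scatter) goes toward a lower number, beyond the scatter. For compound 4 the estimate is 10000 nM, with an expected range of 2500 nM to 40000 nM.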

Compound 4, half-maximal cytotoxic concentration: 115000 nM
Compound 4: middle estimate off by 12-fold (1.06 log units), on the low side; measured number above the stated range.
By their numbers in this assay, from the lowest: compound 3; then compound 1; then compound 4.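

In this assay, 4,4-dimethyl-2-oxopyrrolidin-1-yl in place of 2,4-difluorophenyl gives a 3.6-fold higher number from compound 1 to compound 4 (0.55 log units; beyond the scatter), so this aromatic carbon of the shared core carries a non-aromatic ring without a move toward higher toxicity in this test. Compound 3, which also has a non-aromatic ring with a carbonyl at this place, gives 3560 nM, while compound 4 gives 115000 nM, so such a ring does not by itself lower the number. As far as these compounds go, whether an amine or a carboxylic acid at this place would shift the number remains open. Nothing shown gives a reason for the step.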